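Swapping the dichlorobenzyl of compound 1 for fluorobenzyl

The source may report more compounds than this note shows. Statements on the series, on what has been measured and on what is new or still open speak of the compounds shown alone.

Compound 1 `Nc1cc(N)c2nc(-c3ccccc3)c(NCc3ccc(Cl)c(Cl)c3)nc2c1` was tested in a functional assay on OVCAR-5 cells (Homo sapiens) for inhibition, read by sulforhodamine B assay, with a stated time of 48 h (on this read-out higher numbers stand for weaker inhibition of growth and lower numbers for stronger inhibition of growth), and compound 1 gives 40700 nM. Compound 2 `CCOC(=O)[C@H](CCC(=O)O)NC(=O)c1ccc(Sc2nc3cc(N)cc(N)c3nc2-c2ccccc2)cc1` shares the same core with a longer side chain, and in this assay compound 2 reaches only a limit of the assay, < 100000 nM. Compound 3 `CCOC(=O)[C@H](CCC(=O)O)NC(=O)c1ccc(CNc2nc3cc(N)cc(N)c3nc2-c2ccccc2)cc1` likewise gives in this assay only a limit, < 100000 nM. Compound 1 therefore stands as the one definite number shown, the other two values resting at the limit of < 100000 nM in this assay, at which 2 of the 3 values shown sit.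

Compound 4 `Nc1cc(N)c2nc(-c3ccccc3)c(NCc3ccc(F)cc3)nc2c1` differs from compound 1 in one place: 4-fluorophenyl in place of 3,4-dichlorophenyl on a saturated chain carbon bound to a nitrogen on an aromatic ring. Within the data shown here, no measured pair of compounds that differ in a single place is available, so the size of this step cannot be read from a precedent. With compound 1 already weak at 40700 nM, a step of modest size toward weaker inhibition, or none beyond the scatter, is expected. Compound 4 is estimated at 60000 nM, expected to lie between 15000 nM and 150000 nM. The expected step is a 1.5-fold higher number from compound 1 to compound 4 (0.17 log units; within the scatter).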

Compound 4, concentration for total growth inhibition: 7590 nM
Compound 4: the middle estimate sits 7.9-fold (0.90 log units) above what was measured; measured number below the stated range.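

Among these compounds, exchanging 3,4-dichlorobenzyl for 4-fluorobenzyl gives a 5.4-fold lower number from compound 1 to compound 4 (0.73 log units; beyond the scatter) in this assay, the first step in this set that can be read as a number. It shows that the aryl group on a saturated chain carbon bound to a nitrogen on an aromatic ring is not a silent part of the molecule: changing its halogens moves growth inhibition beyond the scatter, here toward stronger inhibition with the 4-fluorophenyl group. Nothing measured here accounts for the size of this step.

The change removes two chlorines and adds one fluorine in a single move, so the compounds shown cannot tell which part of it carries the step. A 4-chlorobenzyl or a plain benzyl with no halogen would help to separate these parts.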